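The compounds below may be only part of what the source reports. "The series", "measured", "known", "first", "only" and "open" are said of these compounds alone.

Working notes on the series. The shared core of compound 1 `CC(C)c1n[nH]c2c(NCc3ccc(-c4ccccn4)cc3)nc(SCC(O)C(F)(F)F)nc12` is kept throughout; the three measured compounds differ only in the chain on the sulfur. In a functional assay on HT cells (Homo sapiens) for antiproliferative activity, read by fluorescence, with a stated time of 72 h (a lower number here means a stronger inhibitor of growth, a higher number a weaker inhibitor of growth), compound 1 gives 690 nM, compound 2 `CCC(O)CSc1nc(NCc2ccc(-c3ccccn3)cc2)c2[nH]nc(C(C)C)c2n1` gives 273 nM, and compound 3 `CC(C)c1n[nH]c2c(NCc3ccc(-c4ccccn4)cc3)nc(SCC(C)(C)O)nc12` gives 507 nM. Compound 2 sits at the low end of the three numbers: the step of a 2.5-fold lower number from compound 1 to compound 2 (0.40 log units; beyond the scatter) is beyond the scatter, whereas a 1.9-fold higher number from compound 2 to compound 3 (0.27 log units; within the scatter) and a 1.4-fold lower number from compound 1 to compound 3 (0.13 log units; within the scatter) are within it.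

Compound 4 `CCC(CO)Sc1nc(NCc2ccc(-c3ccccn3)cc2)c2[nH]nc(C(C)C)c2n1` is the next candidate, built from compound 2 by 1-(hydroxymethyl)propyl in place of 2-hydroxybutyl on a sulfur. Within the data shown here, no measured step rearranges the chain in this way; the steps that touch the hydroxyl-bearing carbon, a 1.9-fold higher number from compound 2 to compound 3 (0.27 log units; within the scatter) and a 1.4-fold lower number from compound 1 to compound 3 (0.13 log units; within the scatter), stayed within the scatter, and only the trifluoromethyl-to-ethyl step a 2.5-fold lower number from compound 1 to compound 2 (0.40 log units; beyond the scatter) moved beyond it. Because a 1.9-fold higher number from compound 2 to compound 3 (0.27 log units; within the scatter) was within the scatter, a step of similar size is expected here, a 1.3-fold higher number from compound 2 to compound 4 (0.11 log units; within the scatter), in no clear direction. Compound 4 is therefore estimated at 350 nM, with a range of 150 nM to 800 nM in this assay.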

Compound 4, concentration for 50% growth inhibition: 255 nM
Estimate against measurement, compound 4: 1.4-fold (0.14 log units) above, within the range that was stated.
By their numbers in this assay, from the lowest: compounds 4, 2, 3 and 1 (each within the scatter of the next, the first and the last beyond it).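

The exchange of 2-hydroxybutyl for 1-(hydroxymethyl)propyl on a sulfur, with the same atoms joined differently, gives a 1.1-fold lower number from compound 2 to compound 4 (0.03 log units; within the scatter) in this assay and so leaves the two chains unseparated. The 2-hydroxy-2-methylpropyl chain also remains within the scatter of the new chain, with a 2.0-fold lower number from compound 3 to compound 4 (0.30 log units; within the scatter) on record, and the 3,3,3-trifluoro-2-hydroxypropyl chain stands apart from it, with a 2.7-fold lower number from compound 1 to compound 4 (0.43 log units; beyond the scatter) matching the earlier separation seen in a 2.5-fold lower number from compound 1 to compound 2 (0.40 log units; beyond the scatter) as well. Nothing available explains these numbers.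

From the compounds shown here alone, all four chains on the sulfur carry a hydroxyl, so the effect of an amine or a carboxylic acid in its place remains open. Going by these compounds, whether a longer chain holds the numbers seen for compound 2 and compound 4 also remains open.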